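Replacing dimethylamino in compound 3

A few compounds are considered here, and "the series" means these few. Any claim that something is new, unique, unknown or untested is made for them only; others in the source may bear on it.

- compound 1 `CCN1CCN(c2cc(C)c3cc(NC(=O)c4cccc(C)c4)ccc3n2)CC1`: 13700 nM
- compound 2 `CCN1CCN(c2cc(C)c3cc(NC(=O)c4cc(Cl)cc(Cl)c4)ccc3n2)CC1`: 2660 nM
- compound 3 `Cc1cc(N(C)C)nc2ccc(NC(=O)c3ccc(Cl)c(Cl)c3)cc12`: > 50000 nM, a limit

In a functional assay on SK-BR-3 cells (Homo sapiens) for antiproliferative activity, read by MTT assay, with a stated time of 72 h (on this read-out lower numbers stand for stronger inhibition and higher numbers for weaker inhibition), compound 3 gives > 50000 nM, a limit and not a number. Compound 4 `CCN(CC)CCNc1cc(C)c2cc(NC(=O)c3ccc(Cl)c(Cl)c3)ccc2n1` differs by (2-(diethylamino)ethyl)amino in place of dimethylamino on an aromatic carbon, with (2-(diethylamino)ethyl)amino in place of dimethylamino, next to the ring nitrogen. Among the measured compounds shown here, the only measured step, a 5.2-fold lower number from compound 1 to compound 2 (0.71 log units; beyond the scatter), concerns the group on a carbonyl carbon, so it bears on this change only indirectly. At the changed place, compounds 1 and 2 carry a different group and give numbers: compound 1 gives 13700 nM and compound 2 gives 2660 nM. On those values, a clear move to a lower number is expected. The expected size is an at least 12-fold lower number from compound 3 to compound 4 (1.09 log units; beyond the scatter). For compound 4 the estimate is 4000 nM, with an expected range of 1000 nM to 20000 nM.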

Compound 4, half-maximal inhibitory concentration: 3710 nM
For compound 4 the middle estimate is 1.1-fold (0.03 log units) above the measured one, and the stated range covers the measured number.
By their numbers in this assay, from the lowest: compounds 2 and 4 (each within the scatter of the next); then compound 1. At a limit, above all of these: compound 3.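

In this assay, among the compounds shown here, an at least 13-fold lower number from compound 3 to compound 4 (1.12 log units; beyond the scatter) is the first measured change on this aromatic carbon next to the ring nitrogen, and it shows that this place affects the read-out. With (2-(diethylamino)ethyl)amino in place of dimethylamino, compound 4 gives a number. The size of the step remains a bound, as compound 3 gives only a limit: the limit of > 50000 nM in this assay, at which 1 of the 4 values shown sits.

The compounds shown leave open how far the step follows the chain length or the terminal diethylamino group. A longer chain, a morpholine or a carboxylic acid in place of (2-(diethylamino)ethyl)amino remains an open comparison.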